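Swapping an amide substituent in an orexin receptor agonist series

The source may report more compounds than this note shows. Statements on the series, on what has been measured and on what is new or still open speak of the compounds shown alone.

Three compounds have been measured so far in a functional assay on CHO-RD-HGA16 cells for agonist activity at Orexin/Hypocretin receptor type 1 (Homo sapiens), read by fluorescence and calcium flux, with a stated time of 30 min; on this read-out higher numbers stand for an effect only at larger amounts of compound and lower numbers for an effect already at smaller amounts:
Compound 1 `COc1ccc(-c2ccnc(C(=O)N(C)C)c2)cc1S(=O)(=O)Nc1cccc(NCCNC(=O)c2cccc(C)c2)c1` gives 5170 nM.
Compound 2 `COc1ccc(-c2cccc(C(=O)N(C)C)n2)cc1S(=O)(=O)Nc1cccc(NCCNC(=O)c2cccc(C)c2)c1` gives 226 nM.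
Compound 3 `COc1ccc(-c2cccc(C(=O)N(C)CCN(C)C)c2)cc1S(=O)(=O)Nc1cccc(NCCNC(=O)c2cccc(C)c2)c1` gives 638 nM.

Among these three numbers compound 3 stands second highest. Its nearest neighbour is compound 2, whose number is lower, and compound 1 lies furthest away with a higher number. Within the data shown here, the only step between measured compounds that changes a single place, a 23-fold lower number from compound 1 to compound 2 (1.36 log units; beyond the scatter), concerns a change on an aromatic carbon and not the amide nitrogen, so it does not bear on the change considered here.

Compound 4 `COc1ccc(-c2cccc(C(=O)N(C)Cc3ccccn3)c2)cc1S(=O)(=O)Nc1cccc(NCCNC(=O)c2cccc(C)c2)c1` differs from compound 3 only at the substituent on the amide nitrogen: pyridin-2-yl in place of (dimethylamino)methyl on a saturated chain carbon bound to an amide-type nitrogen. Among the measured compounds shown here, no measured step touches this position, so nothing in the data anchors a direction for the change. The step from compound 3 to compound 4 in this assay is therefore expected to be a 1.1-fold lower number from compound 3 to compound 4 (0.03 log units; within the scatter), that is, none beyond the scatter. Compound 4 is expected to give about 600 nM, with a range from 200 nM to 2000 nM.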

Compound 4, half-maximal effective concentration: 235 nM
The estimate for compound 4 lay 2.6-fold (0.41 log units) above the measured number; measured number inside the range.
By their numbers in this assay, from the lowest: compounds 2 and 4 (each within the scatter of the next); then compound 3; then compound 1.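

The substituent on the amide nitrogen is not a silent place in this assay: putting pyridin-2-yl in place of (dimethylamino)methyl on a saturated chain carbon bound to an amide-type nitrogen gives a modest change beyond the scatter (a 2.7-fold lower number from compound 3 to compound 4 (0.43 log units; beyond the scatter)). This single step gives the change a direction, with the compound carrying the aromatic ring producing its effect at smaller amounts than the one carrying the open dimethylamino chain. Nothing measured here explains why the swap acts this way.

On these data alone, it remains open whether the nitrogen of pyridin-2-yl matters at all, and a plain phenyl group at the same place would separate the ring from that nitrogen. Also open, as far as these compounds go, is how a longer chain between the amide nitrogen and the pyridin-2-yl group, or a morpholine in its place, would read in this assay.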